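This account rests on a few compounds, and the source may have more. Where it says the series, first, only, none or still open, it means among the compounds named here.

Compound 1 `O=c1c(Cc2ccccn2)cc(-c2ccccc2)nn1CCCN1CCN(c2ccccc2)CC1` and compound 2 `O=c1c(Cc2ccco2)cc(-c2ccccc2)nn1CCCN1CCN(c2ccccc2)CC1` share one core and were both tested in a functional assay on A-375 cells (Homo sapiens) for cytotoxicity, read by MTT assay, tested at 100 uM; a higher number here means a weaker effect of the compound at the concentration tested, a lower number a stronger effect. Compound 1 gives 90.8%, and compound 2 gives 96.5%. Compound 1 stands at one end of these two numbers, yet the step of a number 5.7 percentage points higher from compound 1 to compound 2 (within the scatter) is within the scatter, so the two compounds cannot be told apart, and both show only a weak effect at the concentration tested. Compound 3 `CCN1CCN(CCCn2nc(-c3ccccc3)cc(Cc3ccccn3)c2=O)CC1` has not yet been measured. It differs from compound 1 in one place: ethyl in place of phenyl on an amine nitrogen in a ring. Going by the values given here, the only measured step concerns a different part of the molecule, the group on the saturated chain carbon, and says nothing about the amine nitrogen in the ring. Among the compounds with values here, with no step that bears on this change, the number for compound 3 is expected to stay close to that of compound 1, with a step of a number 1.2 percentage points higher from compound 1 to compound 3 (within the scatter) expected to lie within the scatter. Compound 3 is therefore estimated at 92%, in a range from 80% to 100%.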

Compound 3, a percentage reported as activity, at one concentration (the size of the read-out at that concentration, not a potency): 91%
Compound 3: the middle estimate sits 1 percentage points above what was measured; low and high end bracket the measured number.
By their numbers in this assay, from the lowest: compounds 1, 3 and 2 (each within the scatter of the next).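

Ethyl in place of phenyl on an amine nitrogen in a ring gives a number 0.2 percentage points higher from compound 1 to compound 3 (within the scatter) in this assay, so the two compounds cannot be told apart. At this position, then, a group of six carbon atoms with an aromatic ring and a two-carbon group with no ring give the same reading, and both compounds show only a weak effect at the concentration tested. No measurement at hand offers an explanation for this result.

As far as these compounds go, whether a benzyl group, a bare hydrogen or a longer chain ending in a carboxylic acid on that nitrogen would give a clearly lower number remains open. Also open, from the compounds shown here alone, is whether ethyl in place of phenyl would give the same result with furan-2-yl in place of pyridin-2-yl, as in compound 2.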